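The source may hold more compounds than are shown below. What is called first, only, known or untested is meant among the compounds shown, and "the series" means these compounds.

In an ADME assay on MT4 cells (Homo sapiens) for cytotoxicity, read by MTT assay, with a stated time of 96 h (a lower number here means that less compound is tolerated, a higher number that more compound is tolerated), compound 1 `Cc1ccc(/N=N/N(C)c2ccccc2)cc1` gives 45000 nM, compound 2 `CN(C)CCCN(/N=N/c1ccc([N+](=O)[O-])cc1)c1ccccc1` gives 20000 nM and compound 3 `CN(C)CCCN(/N=N/c1ccccc1)c1ccccc1` gives 33000 nM. The number for compound 3 lies within the scatter of the numbers for both other compounds.

Compound 4 `Cc1ccc(/N=N/N(CCCN(C)C)c2ccccc2)cc1` differs from compound 3 by methyl in place of hydrogen on an aromatic carbon, para to a large group: methyl in place of hydrogen on an aromatic carbon. For the measured compounds named here, the one measured step of a similar kind is a 1.7-fold higher number from compound 2 to compound 3 (0.22 log units; within the scatter), with hydrogen in place of nitro on an aromatic carbon, and it stays within the scatter. Compound 4 shares the 4-methylphenyl group with compound 1, which gives 45000 nM, but the rest of the two structures differs, so this offers only loose support. No step beyond the scatter is therefore expected in this assay, and no direction is favoured. The expected step is a 1.1-fold lower number from compound 3 to compound 4 (0.04 log units; within the scatter). Compound 4 is estimated at 30000 nM, with an expected range of 15000 nM to 60000 nM.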

Compound 4, half-maximal cytotoxic concentration: 18000 nM
Estimate against measurement, compound 4: 1.7-fold (0.22 log units) above, within the range that was stated.
By their numbers in this assay, from the lowest: compounds 4, 2, 3 and 1 (each within the scatter of the next, the first and the last beyond it).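

In this assay, three ring groups can now be compared at this position, para to a large group: hydrogen, nitro and methyl. Methyl in place of hydrogen (a 1.8-fold lower number from compound 3 to compound 4 (0.26 log units; within the scatter)) and methyl in place of nitro (a 1.1-fold lower number from compound 2 to compound 4 (0.05 log units; within the scatter)) both stay within the scatter, so neither change separates these compounds. With the 4-methylphenyl group held constant, 2-(dimethylamino)ethyl in place of hydrogen on a saturated chain carbon bound to a nitrogen on an aromatic ring gives a modest step beyond the scatter (a 2.5-fold lower number from compound 1 to compound 4 (0.40 log units; beyond the scatter)), and nothing measured accounts for it.

As far as these compounds go, whether a carboxylic acid or a methoxy group on this aromatic carbon would leave the number within the scatter remains open. Also open, from the compounds shown here alone, is whether a longer chain or a morpholine at the chain end would move it further.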